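Swapping a para substituent on the pendant phenyl ring

The compounds below may be only part of what the source reports. "The series", "measured", "known", "first", "only" and "open" are said of these compounds alone.

Measured compounds:
compound 1 `Brc1cn2ccnc2c(-c2ccc3ncn(C4CCCCC4)c3c2)n1`, 18.1%
compound 2 `COc1ccc(-c2cn3ccnc3c(-c3ccc4ncn(C5CCCCC5)c4c3)n2)cc1`, 31.5%
compound 3 `CC(=O)c1ccc(-c2cn3ccnc3c(-c3ccc4ncn(C5CCCCC5)c4c3)n2)cc1`, 1.19%

In a functional assay on NCI-H322M cells (Homo sapiens) for inhibition, read by sulforhodamine B assay, with a stated time of 48 h, tested at 10 uM (on this read-out lower numbers stand for less inhibition and higher numbers for more inhibition at the one concentration tested (going by the name of the read-out)), compound 3 gives 1.19%, the lowest of the three numbers; the nearest is compound 1 and the furthest compound 2, both separated from it beyond the scatter. Compound 4 `Brc1ccc(-c2cn3ccnc3c(-c3ccc4ncn(C5CCCCC5)c4c3)n2)cc1` has not yet been tested. It differs from compound 3 by bromo in place of acetyl on an aromatic carbon. Among the compounds with values here, no measured step has a bromo group entering at this position, so the closest guidance is the step in which acetyl entered, a number 30.3 percentage points lower from compound 2 to compound 3 (beyond the scatter), together with the gap between compound 1 and compound 2, a number 13.4 percentage points higher from compound 1 to compound 2 (beyond the scatter). Because compound 3 sits lowest with 1.19% and the acetyl group is removed in the step from compound 3 to compound 4, the expectation is a modest rise in this assay, a number 13.8 percentage points higher from compound 3 to compound 4 (beyond the scatter), though the absence of any directly comparable bromo step leaves that expectation loose. The estimated value for compound 4 is 15%, with a range from 0% to 35%.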

Compound 4, a percentage reported as inhibition, at one concentration (the size of the read-out at that concentration, not a potency): 4.21%
For compound 4 the middle estimate is 10.8 percentage points above the measured one; the measured number falls inside the stated range.
By their numbers in this assay, from the lowest: compounds 3 and 4 (each within the scatter of the next); then compound 1; then compound 2.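

In this assay, the exchange at this carbon, para to a large group, gives a number 3 percentage points higher from compound 3 to compound 4 (within the scatter) and so does not separate bromo from acetyl. Against bromo, methoxy still stands apart, with a number 27.3 percentage points lower from compound 2 to compound 4 (beyond the scatter) showing that the large drop seen with acetyl is not peculiar to that group. The aryl extension also does not act the same way in every case: a number 13.9 percentage points lower from compound 1 to compound 4 (beyond the scatter) shows that 4-bromophenyl gives a lower number than bromo, whereas compound 2 goes the other way.

No evidence is available to explain why methoxy differs from the other two groups. Going by these compounds, whether an amine, a carboxylic acid or a longer alkoxy chain at this position would read like methoxy, or like bromo and acetyl, remains open.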